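A few compounds are considered here, and "the series" means these few. Any claim that something is new, unique, unknown or untested is made for them only; others in the source may bear on it.

Compound 1 `COCCNC(=O)c1cc2cccc(OC)c2oc1=N` is one of three compounds sharing a core that have been measured in an assay on HeLa cells for displacement of a labelled ligand from adenosine receptor A3 (Homo sapiens), read by scintillation counting, with a stated time of 180 min, tested at 10 uM; on this read-out lower numbers stand for less inhibition and higher numbers for more inhibition at the one concentration tested (going by the name of the read-out). In this assay compound 1 gives 15%. Compound 2 `COc1cc(Br)cc2cc(C(=O)NCCCO)c(=N)oc12` carries a bromine on the core and a hydroxyl-ended chain on the amide, and in this assay compound 2 gives 23%. Compound 3 `O=C(NCC(O)CO)c1cc2cccc(O)c2oc1=O` has a hydroxyl on the core and a dihydroxylated chain on the amide, and in this assay compound 3 gives 22%. The gaps from compound 1 to compound 3 and from compound 1 to compound 2 both lie within the usual scatter, so the three numbers cannot be told apart.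

Compound 4 `COc1cccc2cc(C(=O)NCCCCCO)c(=N)oc12` has not yet been measured in this assay. It differs from compound 1 in one place: 3-hydroxypropyl in place of methoxy on a saturated chain carbon, two bonds along the chain from an amide-type nitrogen. The hydroxyl-ended chains of compound 2 and compound 3 have not moved the numbers beyond the scatter, so no firm direction can be read from them. Compound 4 is therefore expected to show a step of a number 5 percentage points higher from compound 1 to compound 4 (within the scatter), that is, nothing beyond the scatter. For compound 4 the estimate in this assay is 20%, with a range from 8% to 32%.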

Compound 4, a percentage reported as inhibition, at one concentration (the size of the read-out at that concentration, not a potency): 13%
Compound 4: the middle estimate sits 7 percentage points above what was measured; measured number inside the range.
By their numbers in this assay, from the lowest: compounds 4, 1, 3 and 2 (each within the scatter of the next).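

In this assay, putting 3-hydroxypropyl in place of methoxy on a saturated chain carbon, two bonds along the chain from an amide-type nitrogen, gives a number 2 percentage points lower from compound 1 to compound 4 (within the scatter). Among these compounds, this is the first comparison in which only this one place differs, and it shows that a group with more heavy atoms and a hydrogen-bond donor can enter here without the number moving beyond the scatter, something compound 2 and compound 3 could not show because they also differ from compound 1 elsewhere. No supporting measurement bears on this result.

Still open, on these data alone, is whether a different ending on this chain, such as an amine or a carboxylic acid, or a ring at this place, would move the number beyond the scatter. Also open, as far as these compounds go, is whether the same change would give a similar step on a core carrying the bromine of compound 2, and how the compounds would compare at other concentrations, since a reading at a single concentration is not a potency.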